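Alkoxy variation on the shared core: step to compound 4

This account rests on a few compounds, and the source may have more. Where it says the series, first, only, none or still open, it means among the compounds named here.

Measured so far:
compound 1, `CCCCNc1nc(N)nnc1OC(C)C`: 460 nM
compound 2, `CCCCNc1nc(N)nnc1OCc1ccccc1F`: 560 nM
compound 3, `CCCCNc1nc(N)nnc1OCc1cccnc1`: 590 nM

In an assay on isolated protein for agonist activity at Toll-like receptor 8 (Homo sapiens) (a lower number here means that less compound is needed, a higher number that more compound is needed for the effect), compound 3 gives the highest of the three numbers, yet its gap to compound 2 and to compound 1 lies within the scatter, so no order among the three can be read. Going by the values given here, the one measured step, a 1.1-fold higher number from compound 2 to compound 3 (0.02 log units; within the scatter), changed the group on the ether carbon without effect beyond scatter.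

Compound 4, `CCCCNc1nc(N)nnc1OCCCN(C)C`, differs from compound 3 as follows: 2-(dimethylamino)ethyl in place of pyridin-3-yl on a saturated chain carbon bound to an oxygen on an aromatic ring

Among the compounds with values here, only that one step bears on the change, and it was flat; the group entering here has no ring, for which no measured comparison exists. The expected step of a 1.1-fold higher number from compound 3 to compound 4 (0.04 log units; within the scatter) is therefore none beyond the scatter, and compound 4 is estimated at 650 nM, range 250 nM to 1700 nM.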

Compound 4, half-maximal effective concentration: 100 nM
Beside the measured number, compound 4's estimate is 6.5-fold (0.81 log units) above it, and the stated range ends above it.
By their numbers in this assay, from the lowest: compound 4; then compounds 1, 2 and 3 (each within the scatter of the next).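

At this position, on an oxygen on an aromatic ring, the group now moves the number in this assay: a 5.9-fold lower number from compound 3 to compound 4 (0.77 log units; beyond the scatter), a 5.6-fold lower number from compound 2 to compound 4 (0.75 log units; beyond the scatter) and a 4.6-fold lower number from compound 1 to compound 4 (0.66 log units; beyond the scatter). Going by these compounds alone, the earlier isopropyl, 2-fluorophenyl and pyridin-3-yl compounds gave no step beyond the scatter, so compound 4, with its dimethylamino-bearing chain, is the first to separate from the others. Nothing measured here accounts for these steps.

Open, as far as these compounds go, is whether the dimethylamino group or the chain carries the step. A plain butyl chain, a carboxylic acid or a longer chain ending in dimethylamino would separate the two.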